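Phenethyl in Place of Fluorophenyl on the Sulfur of Compound 1

The compounds below may be only part of what the source reports. "The series", "measured", "known", "first", "only" and "open" are said of these compounds alone.

Measured so far in a functional assay on A549 cells (Homo sapiens) for inhibition, read by CCK-8 assay, with a stated time of 72 h, tested at 8 uM; a lower number here means less inhibition of growth, a higher number more inhibition of growth at the concentration tested:
compound 1 `Nc1ccccc1NC(=O)/C=C/c1ccc(CSc2ccc(F)cc2)cc1` — 59.1%
compound 2 `CC(C)(C)c1ccc(SCc2ccc(C(=O)Nc3ccccc3N)cc2)cc1` — 67%
compound 3 `CCc1ccc(SCc2ccc(C(=O)Nc3ccccc3N)cc2)cc1` — 91.4%

Compound 1 stands at the smallest of the three numbers, but its gap to compound 2 is within the scatter; only compound 3 lies beyond it. Within the data shown here, the one measured step, a number 24.4 percentage points higher from compound 2 to compound 3 (beyond the scatter), concerns an ethyl in place of a tert-butyl on an aromatic carbon, in two compounds whose shared core lacks the unsaturated linker of compound 1. It does not touch the place that changes here.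

The unmeasured compound 4 `Nc1ccccc1NC(=O)/C=C/c1ccc(CSCCc2ccccc2)cc1` differs from compound 1 in one place: phenethyl in place of 4-fluorophenyl on a sulfur. Among the measured compounds shown here, no measured pair shows a change at this sulfur, and no measured compound carries a phenethyl group, so nothing in the data sets a direction for this step.

Given that lack, the expectation is no step beyond the scatter: the estimated change is a number 0.9 percentage points higher from compound 1 to compound 4 (within the scatter). Compound 4 is therefore expected to give about 60%, with a range from 35% to 85%, the breadth reflecting that the step is unsupported by any measured comparison.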

Compound 4, percent growth inhibition at one concentration: 50.3%
Compound 4: the middle estimate sits 9.7 percentage points above what was measured; the measured number falls inside the stated range.
By their numbers in this assay, from the lowest: compounds 4, 1 and 2 (each within the scatter of the next, the first and the last beyond it); then compound 3.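

In this assay, among these compounds, this pair gives the first reading of a change at the sulfur: a number 8.8 percentage points lower from compound 1 to compound 4 (within the scatter). The step does not pass the scatter, so at the one concentration tested, this assay does not separate 4-fluorophenyl from phenethyl on this sulfur, although the two groups differ in their atoms and each carries one six-membered aromatic ring of carbon only. No measured property of these compounds bears on this result, so it gives no account of how the groups compare beyond the growth inhibition itself.

The pair changes the fluorine and the group's carbon count together, so the compounds shown leave open what a plain phenyl or a benzyl on the sulfur would give, and whether a group with no aromatic ring, such as a simple ethyl, an amine or a carboxylic acid on a longer chain, would stay within the scatter of compound 1. They also leave open whether the same exchange would give a similar step on the core shared by compound 2 and compound 3, which lacks the unsaturated linker.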